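The source may report more compounds than this note shows. Statements on the series, on what has been measured and on what is new or still open speak of the compounds shown alone.

Measured in a functional assay on A-375 cells (Homo sapiens) for antiproliferative activity; on this read-out higher numbers stand for weaker inhibition and lower numbers for stronger inhibition:
compound 1 `CC1=C/C(=C\C(C)C)C(=O)C(C)(O)C12CC2` gives 130 nM
compound 2 `C/C=C1\C=C(C)C2(CC2)C(C)(O)C1=O` gives 4 nM

Among the compounds with values here, compound 2 stands at the lowest of the two numbers, and its only measured neighbour is compound 1, from which it is separated by a 33-fold lower number from compound 1 to compound 2 (1.51 log units; beyond the scatter). Within the data shown here, that step is the one piece of evidence bearing on the next compound.

Compound 3 `CC1=C/C(=C\Cl)C(=O)C(C)(O)C12CC2` has not yet been measured. It differs from compound 2 by chloro in place of methyl on a double-bonded chain carbon bound to a double-bonded ring carbon. The measured step concerned the very same place on the molecule, where isopropyl became methyl and the number fell sharply; it therefore shows that this place matters, but it says nothing directly about chloro. Among the measured compounds shown here, since chloro and methyl are both single-atom groups in the counted difference, and no compound here carries a halogen, the expectation rests on the position being tolerant of a small group, as it was for compound 2 with 4 nM.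

A step of about a 1.5-fold higher number from compound 2 to compound 3 (0.18 log units; within the scatter) is expected from compound 2 to compound 3, within the usual scatter. For compound 3 the estimated value is 6 nM, with a range from 2 nM to 25 nM.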

Compound 3, half-maximal inhibitory concentration: 1000 nM
Beside the measured number, compound 3's estimate is 170-fold (2.22 log units) below it; the measured number lies above the stated range.
By their numbers in this assay, from the lowest: compound 2; then compound 1; then compound 3.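

In this assay, replacing methyl with chloro on a double-bonded chain carbon bound to a double-bonded ring carbon gives a 250-fold higher number from compound 2 to compound 3 (2.40 log units; beyond the scatter) and shows that two groups, each counted as a single heavy atom, can give very different results at this place, so a small heavy-atom count alone does not secure a low number. Replacing isopropyl with chloro gives a 7.7-fold higher number from compound 1 to compound 3 (0.89 log units; beyond the scatter) and places chloro behind isopropyl, so across these three compounds the numbers do not rise in step with heavy-atom count, and compound 3 goes against any such trend. The change itself is clear, but nothing available here explains why chloro differs so sharply from methyl.

The compounds shown leave open whether fluoro or bromo at this place would give a number as high as chloro does, and whether ethyl or methoxy would stay close to methyl. They also cannot tell whether chloro would have a similar effect with any change elsewhere on the shared core.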